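Swapping the ring sulfonamide for a carbamate

A few compounds are considered here, and "the series" means these few. Any claim that something is new, unique, unknown or untested is made for them only; others in the source may bear on it.

Compound 1 `Cn1cncc1CN1CC(N(CC2CCN(S(C)(=O)=O)CC2)S(=O)(=O)c2ccccn2)Cc2cc(C#N)ccc21` is the reference point of this small set. In an ADME assay on Caco-2 cells (Homo sapiens) for permeability, in the apical to basolateral direction (a lower number here means that the compound crosses the layer more slowly, a higher number that the compound crosses the layer faster), compound 1 gives 0.1 10^-6 cm/s, the lowest of the three numbers measured. Compound 2 `Cn1cncc1CN1CC(N(CC2CCN(C(=O)Nc3ccc(Br)cc3)CC2)S(=O)(=O)c2ccccn2)Cc2cc(C#N)ccc21` gives 0.6 10^-6 cm/s and compound 3 `Cn1cncc1CN1CC(N(CC2CCN(C(=O)c3ccco3)CC2)S(=O)(=O)c2ccccn2)Cc2cc(C#N)ccc21` gives 0.5 10^-6 cm/s; the step of a 1.2-fold lower number from compound 2 to compound 3 (0.08 log units; within the scatter) lies within the scatter, so nothing separates those two.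

The unmeasured compound 4 `Cn1cncc1CN1CC(N(CC2CCN(C(=O)OCc3ccccc3)CC2)S(=O)(=O)c2ccccn2)Cc2cc(C#N)ccc21` differs from compound 1 in one place: benzyloxycarbonyl in place of methylsulfonyl on an amine nitrogen in a ring. Among the measured compounds shown here, two measured steps bear on it directly, since both also exchange the methylsulfonyl on that ring nitrogen for a carbonyl-bearing group. The step of a 6.0-fold higher number from compound 1 to compound 2 (0.78 log units; beyond the scatter) and the step of a 5.0-fold higher number from compound 1 to compound 3 (0.70 log units; beyond the scatter) each lie beyond the scatter and point the same way. A benzyloxycarbonyl is a third carbonyl-bearing replacement at the same position, so compound 4 is expected to follow the same direction, with a step of roughly the size seen for compound 2 and compound 3, perhaps somewhat larger given the added aromatic ring.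

The expected step is therefore a 7.0-fold higher number from compound 1 to compound 4 (0.85 log units; beyond the scatter). Compound 4 is estimated at 0.7 10^-6 cm/s, within a range from 0.3 10^-6 cm/s to 1.8 10^-6 cm/s.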

Compound 4, apparent permeability: 1 10^-6 cm/s
Compound 4: the middle estimate sits 1.4-fold (0.15 log units) below what was measured; low and high end bracket the measured number.
By their numbers in this assay, from the lowest: compound 1; then compounds 3, 2 and 4 (each within the scatter of the next).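

At this ring nitrogen, a third carbonyl-bearing group in place of methylsulfonyl moves this assay the same way as the first two, with a 10-fold higher number from compound 1 to compound 4 (1.00 log units; beyond the scatter), so the direction now holds for a carbamate as well as for the groups in compound 2 and compound 3, and none of the three goes against it. The three replacements are not separated from one another, since a 2.0-fold higher number from compound 3 to compound 4 (0.30 log units; within the scatter) and a 1.7-fold higher number from compound 2 to compound 4 (0.22 log units; within the scatter) both lie within the scatter, and benzyloxy, furan-2-yl and (4-bromophenyl)amino on the carbonyl carbon therefore cannot be ranked here. No measured evidence is at hand to explain the difference from methylsulfonyl.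

Every replacement shown carries both a carbonyl and an aromatic ring, so the compounds leave open which of the two goes with the higher number: an acetyl on the same nitrogen would have the carbonyl without the ring, and a benzyl would have the ring without the carbonyl. They also leave open whether the methylsulfonyl result belongs to the sulfonyl itself or to its small methyl, a question that a phenylsulfonyl at this position would address.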